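A dihydroxyphenyl exchange on the shared core

The source may report more compounds than this note shows. Statements on the series, on what has been measured and on what is new or still open speak of the compounds shown alone.

Measured in a functional assay on DU-145 cells (Homo sapiens) for cytotoxicity; on this read-out higher numbers stand for weaker inhibition of growth and lower numbers for stronger inhibition of growth
compound 1 `COc1ccc(C2=C(c3ccc(SC)cc3)CC3CCCN3C2=O)cc1Br` gives 900 nM
compound 2 `CSc1ccc(C2=C(c3ccc(C)c(C)c3)C(=O)N3CCCC3C2)cc1` gives 500 nM

Compound 2 has a single measured neighbour, and the two numbers lie within the scatter of each other. Among the compounds with values here, the one measured step is a 1.8-fold lower number from compound 1 to compound 2 (0.26 log units; within the scatter) and it comes from an exchange on the same double-bonded ring carbon, with 3,4-dimethylphenyl in place of 3-bromo-4-methoxyphenyl. Compound 3 `CSc1ccc(C2=C(c3ccc(O)c(O)c3)C(=O)N3CCCC3C2)cc1` differs at that carbon again, with 3,4-dihydroxyphenyl in place of 3,4-dimethylphenyl, and the counted difference is 3,4-dihydroxyphenyl in place of 3,4-dimethylphenyl on a double-bonded ring carbon in full. Within the data shown here, no measured compound has a hydroxy group on this ring, so the data give no direct guide to it. With only a 1.8-fold lower number from compound 1 to compound 2 (0.26 log units; within the scatter) to go by, no step beyond the scatter is expected, though the uncertainty stays wide. The estimated step is a 1.6-fold higher number from compound 2 to compound 3 (0.20 log units; within the scatter) at the middle of the range. For compound 3 the expected value is 800 nM with an estimated range from 200 nM to 3500 nM around it.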

Compound 3, concentration for 50% growth inhibition: 60000 nM
Estimate against measurement, compound 3: 75-fold (1.88 log units) below; measured number outside the range, above it.
By their numbers in this assay, from the lowest: compounds 2 and 1 (each within the scatter of the next); then compound 3.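

In this assay the double-bonded ring carbon turns out to be sensitive to the group it carries: 3,4-dihydroxyphenyl in place of 3,4-dimethylphenyl gives a 120-fold higher number from compound 2 to compound 3 (2.08 log units; beyond the scatter) even though the two groups have the same number of heavy atoms, and only the entering group has hydrogen-bond donors and acceptors. The exchange of 3-bromo-4-methoxyphenyl for 3,4-dihydroxyphenyl is also large, with a 67-fold higher number from compound 1 to compound 3 (1.82 log units; beyond the scatter) set beside it, so the groups of compound 1 and compound 2, whose numbers lie within the scatter of each other, both stand well apart from the group of compound 3. Nothing available explains this difference.

The compounds shown leave open whether a phenyl ring with a single hydroxy group behaves like that of compound 3 or like those of compound 1 and compound 2. They also do not show how a phenyl ring bearing an amine or a carboxylic acid would fare at this position.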